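The source may hold more compounds than are shown below. What is called first, only, known or untested is meant among the compounds shown, and "the series" means these compounds.

In a physicochemical assay for lipophilicity (on this read-out lower numbers stand for lower lipophilicity and higher numbers for higher lipophilicity), compound 1 `COc1ccc(C2C[C@@]3(ON2c2ccccc2)C(=O)O[C@@H]2[C@H]3CC[C@H](C)[C@]3(O)C=CC(=O)[C@@]23C)cc1` gives 3.25, compound 2 `C[C@H]1CC[C@@H]2[C@@H](OC(=O)[C@]23CC(c2cccc(Cl)c2)N(c2ccccc2)O3)[C@]2(C)C(=O)C=C[C@@]12O` gives 3.87 and compound 3 `COc1ccc(C2C[C@@]3(ON2c2ccccc2)C(=O)O[C@@H]2[C@H]3CC[C@H](C)[C@]3(O)C=CC(=O)[C@@]23C)cc1Br` gives 3.98. Compound 3 is thus placed by two steps: a number 0.11 log units higher from compound 2 to compound 3 (within the scatter) and a number 0.73 log units higher from compound 1 to compound 3 (beyond the scatter). In compound 4 `C[C@H]1CC[C@@H]2[C@@H](OC(=O)[C@]23CC(c2c(F)c(F)c(F)c(F)c2F)N(c2ccccc2)O3)[C@]2(C)C(=O)C=C[C@@]12O`, 2,3,4,5,6-pentafluorophenyl takes the place of 3-bromo-4-methoxyphenyl on a saturated ring carbon (2,3,4,5,6-pentafluorophenyl in place of 3-bromo-4-methoxyphenyl on a saturated ring carbon). For the measured compounds named here, no measured compound carries fluorine, so the evidence is indirect. The closest guide is that the two measured compounds with a halogen on this aromatic ring agree within the scatter, while compound 1, without one, differs by a number 0.62 log units higher from compound 1 to compound 2 (beyond the scatter). No change beyond the scatter is therefore expected in this assay, and the expected step is a number 0.08 log units lower from compound 3 to compound 4 (within the scatter). For compound 4, the estimated value is 3.9, with an expected range from 3.5 to 4.3.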

Compound 4, partition coefficient: 3.72
Beside the measured number, compound 4's estimate is 0.18 log units above it, within the range that was stated.
By their numbers in this assay, from the lowest: compound 1; then compounds 4, 2 and 3 (each within the scatter of the next).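

In this assay, 2,3,4,5,6-pentafluorophenyl on the saturated ring carbon places compound 4 with the other halogen-bearing compounds, as a number 0.26 log units lower from compound 3 to compound 4 (within the scatter) and a number 0.15 log units lower from compound 2 to compound 4 (within the scatter) show, while a number 0.47 log units higher from compound 1 to compound 4 (beyond the scatter) separates it from the compound without halogen. Across the compounds shown, then, this position tolerates quite different halogen patterns in this assay without a change beyond the scatter. Nothing available explains this result. Going by these compounds, whether a ring carrying an amine or a carboxylic acid instead of halogen would fall with compound 1 or with the halogen-bearing compounds remains open.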